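The compounds below may be only part of what the source reports. "The series", "measured", "known", "first", "only" and "open" are said of these compounds alone.

Within the data shown here, in a functional assay on MCF7 cells (Homo sapiens) for antiproliferative activity, read by sulforhodamine B assay, with a stated time of 72 h (on this read-out higher numbers stand for weaker inhibition and lower numbers for stronger inhibition), compound 1 `COc1cccc(/C=C2\CCC=CC2=O)c1` gives 2030 nM, the lower of the two numbers measured so far, while compound 2 `COc1cccc(/C=C2\CCC=CC2=O)c1OC` gives 4710 nM. Compound 3 `COc1cc(/C=C2\CCC=CC2=O)cc(OC)c1` has not yet been measured. Its structure departs from that of compound 1 by one change, methoxy in place of hydrogen on an aromatic carbon. The new group stands meta to the methoxy group already present. Among the measured compounds shown here, only one measured step involves the same kind of change: a 2.3-fold higher number from compound 1 to compound 2 (0.37 log units; beyond the scatter). For the measured compounds named here, that modest step is the sole guide, and it comes from a different compound, so it suggests a direction more firmly than a size. A similar or smaller rise in the number is therefore expected in this assay. The estimated change is a 1.6-fold higher number from compound 1 to compound 3 (0.20 log units; within the scatter). For compound 3 the expected value is 3200 nM, with an estimated range from 1300 nM to 7500 nM.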

Compound 3, half-maximal inhibitory concentration: 4620 nM
Estimate against measurement, compound 3: 1.4-fold (0.16 log units) below, and the stated range covers the measured number.
By their numbers in this assay, from the lowest: compound 1; then compounds 3 and 2 (each within the scatter of the next).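

In this assay a methoxy group on the aromatic carbon meta to the methoxy group already present gives a 2.3-fold higher number from compound 1 to compound 3 (0.36 log units; beyond the scatter) and thus shows that the earlier rise is not confined to a single placement. Compound 2 and compound 3 differ only in where the added methoxy sits, and their numbers lie within the scatter of each other, so these two placements cannot be told apart in this read-out. No measurement at hand bears on the reason for this rise.

Going by these compounds, whether another group on this aromatic carbon, such as a hydroxyl, an amine or a fluorine, would move the number the same way remains open. So does the effect of a longer chain, such as ethoxy, in place of the added methoxy.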